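A few compounds are considered here, and "the series" means these few. Any claim that something is new, unique, unknown or untested is made for them only; others in the source may bear on it.

Working notes on the series.

For the measured compounds named here, compound 2 `COc1ncc(-c2ccn3nc(NC(C)=O)nc3c2)cc1NS(=O)(=O)c1ccc(F)cc1` is one of two compounds measured so far in a functional assay on HCT-116 cells (Homo sapiens) for antiproliferative activity, read by MTT assay, with a stated time of 48 h; a lower number here means a stronger inhibitor, a higher number a weaker inhibitor. In this assay compound 2 gives 1320 nM. Its nearest neighbour is compound 1 `COc1ncc(-c2ccn3nc(NC(C)=O)nc3c2)cc1NS(=O)(=O)c1ccc(C)cc1`, which carries a methyl where compound 2 carries a fluoro on the sulfonamide aryl ring; in this assay compound 1 gives 1380 nM. The one step measured, a 1.0-fold lower number from compound 1 to compound 2 (0.02 log units; within the scatter), changes nothing beyond the scatter, so compound 2 and compound 1 stand together on the numbers shown.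

Compound 3 `COc1ncc(-c2ccn3nc(N)nc3c2)cc1NS(=O)(=O)c1ccc(F)cc1` keeps the fluoro of compound 2 and differs only at the other end of the molecule: hydrogen in place of acetyl on a nitrogen on an aromatic ring, so that the acetamido of compound 2 becomes an amino in compound 3. Going by the values given here, no measured step touches this position; the single step known concerns the sulfonamide aryl ring and was within the scatter, so it gives no guide to the size or direction of a change at the ring nitrogen. The expectation for compound 3 therefore rests on compound 2 alone and is held wide: the step of a 1.1-fold higher number from compound 2 to compound 3 (0.06 log units; within the scatter) is estimated as no more than scatter around compound 2. Compound 3 is expected to give about 1500 nM in this assay, with a plausible range from 400 nM to 6000 nM.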

Compound 3, half-maximal inhibitory concentration: 820 nM
Estimate against measurement, compound 3: 1.8-fold (0.26 log units) above; measured number inside the range.
By their numbers in this assay, from the lowest: compounds 3, 2 and 1 (each within the scatter of the next).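

For the compounds shown here, the step of a 1.6-fold lower number from compound 2 to compound 3 (0.21 log units; within the scatter) is the first reading at this end of the molecule in this assay, and it concerns hydrogen in place of acetyl on a nitrogen on an aromatic ring. It shows that the acetamido of compound 2 can be cut back to the amino of compound 3 without a difference beyond the scatter, so the whole acetyl is not needed to hold the activity at the level seen for compound 2, and the two compounds stand together on the numbers. Nothing measured on these compounds accounts for this result or links it to any property of the acetyl or amino group, so the step can be read only as a size.

Open, from the compounds shown here alone, is whether a longer acyl chain, a methyl or a carboxylic acid-bearing chain on this nitrogen would give a number beyond the scatter from compound 2 and compound 3, since only acetyl and hydrogen appear there. Also open, going by these compounds, is whether an amino at this position behaves the same with a methyl on the sulfonamide aryl ring, or with a chloro or methoxy in place of the fluoro of compound 3.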